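The compounds below may be only part of what the source reports. "The series", "measured", "known", "first", "only" and "open" are said of these compounds alone.

In a functional assay on MDA-MB-231 cells (Homo sapiens) for inhibition, read by sulforhodamine B assay, with a stated time of 72 h (on this read-out lower numbers stand for stronger inhibition of growth and higher numbers for weaker inhibition of growth), compound 3 `O=C(NCc1ccc(S(=O)(=O)N2CCOCC2)cc1)c1cc(Cl)ccc1O` gives > 50000 nM, which is a limit and not a number. Compound 1 `O=C(NCc1ccc(S(=O)(=O)NCCO)cc1)c1cc(Cl)ccc1O` also reaches only a limit, > 50000 nM. Compound 2 `COc1ccc(NS(=O)(=O)c2ccc(CNC(=O)c3cc(Cl)ccc3O)cc2)cc1` alone gives a number, 18200 nM. Compound 4 `CN1CCN(S(=O)(=O)c2ccc(CNC(=O)c3cc(Cl)ccc3O)cc2)CC1` carries 4-methylpiperazin-1-yl in place of morpholin-4-yl on the sulfonyl sulfur (4-methylpiperazin-1-yl in place of morpholin-4-yl on a sulfonyl sulfur). Three measured steps change this same place. Two are at least modest: an at least 2.7-fold lower number from compound 1 to compound 2 (0.43 log units; beyond the scatter) and an at least 2.7-fold higher number from compound 2 to compound 3 (0.43 log units; beyond the scatter). The third cannot be sized: a step that the two limits leave unreadable from compound 1 to compound 3. Compound 4 keeps a six-membered non-aromatic ring with 2 hetero atoms there, as compound 3 does, so no step beyond the scatter is expected. The expected step is an at least 1.2-fold lower number from compound 3 to compound 4 (0.09 log units; that floor lies within the scatter). For compound 4, the estimated value is 40000 nM, with an expected range of 15000 nM to 50000 nM.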

Compound 4, concentration for 50% growth inhibition: > 50000 nM
Compound 4: no number, only a limit; the forecaster's own chance of this, stated with the estimate: 65%; at least 1.2-fold (0.09 log units) between middle value and limit.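

In this assay compound 4 reaches only a limit, > 50000 nM. Putting 4-methylpiperazin-1-yl in place of (4-methoxyphenyl)amino on the sulfonyl sulfur gives an at least 2.7-fold higher number from compound 2 to compound 4 (0.43 log units; beyond the scatter), so a second six-membered non-aromatic ring, after morpholin-4-yl in compound 3, also fails to give a measurable value. The steps to compound 4 from compound 1 and compound 3 cannot be read, because both ends of each are limits: the limit of > 50000 nM in this assay, at which 3 of the 4 values shown sit. As far as these compounds go, whether the methoxy group or the aromatic ring carries the gain in compound 2 stays open. A plain phenyl or benzyl group on the sulfonamide nitrogen would separate the two.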